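A few compounds are considered here, and "the series" means these few. Any claim that something is new, unique, unknown or untested is made for them only; others in the source may bear on it.

Two compounds share one core and differ only in the group on an aromatic carbon. Compound 1 `CC(C)c1ccc(NC(=O)c2cc3ccccc3oc2=O)cc1` gives 15100 nM in an in vitro assay on BTI-TN-5B1-4 cells for inhibition of Amine oxidase [flavin-containing] A (Homo sapiens), read by fluorescence; a higher number here means a weaker inhibitor, a lower number a stronger inhibitor. Compound 2 `CSc1ccc(NC(=O)c2cc3ccccc3oc2=O)cc1` gives 14800 nM in this assay and stands beside compound 1, with the step of a 1.0-fold lower number from compound 1 to compound 2 (0.01 log units; within the scatter) showing no difference beyond the scatter. Compound 3 `O=C(Nc1ccc(F)cc1)c1cc2ccccc2oc1=O` is not yet measured. It differs from compound 2 by fluoro in place of methylsulfanyl on an aromatic carbon. Among the compounds with values here, the only measured step at this place, a 1.0-fold lower number from compound 1 to compound 2 (0.01 log units; within the scatter), was flat, so no step beyond the scatter is expected in this assay. Compound 3 is therefore estimated at 15000 nM, with a range from 5000 nM to 45000 nM. The expected step is a 1.0-fold higher number from compound 2 to compound 3 (0.01 log units; within the scatter).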

Compound 3, half-maximal inhibitory concentration: 13100 nM
Beside the measured number, compound 3's estimate is 1.1-fold (0.06 log units) above it; measured number inside the range.
By their numbers in this assay, from the lowest: compounds 3, 2 and 1 (each within the scatter of the next).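

In this assay the flat picture now extends to fluoro, a group of a single heavy atom: replacing methylsulfanyl gives a 1.1-fold lower number from compound 2 to compound 3 (0.05 log units; within the scatter) and replacing isopropyl gives a 1.2-fold lower number from compound 1 to compound 3 (0.06 log units; within the scatter). The three groups at this place, para to a large group, therefore give numbers that cannot be told apart, even though they differ in their atoms. No measurement at hand explains this flatness. Still open, as far as these compounds go, is whether any group here can move the number beyond the scatter, such as an amine, a carboxylic acid or a longer chain.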